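Swapping a cyclopentyl for a trifluoromethyl-bearing chain

The source may report more compounds than this note shows. Statements on the series, on what has been measured and on what is new or still open speak of the compounds shown alone.

Of the compounds shown here, two sharing one core have been measured in an assay on CHO cells for activation of Guanylate cyclase soluble subunit alpha-1 (Rattus norvegicus), read by luminescence and cGMP accumulation, with a stated time of 6 min; a higher number here means a larger maximal response, a lower number a smaller maximal response. Compound 1 `Cc1c(CCC(=O)O)cccc1NC(=O)[C@H](c1ccc(CN2N=C(c3ccccc3)OCC2=O)cc1)C1CCCC1` gives 110% in this assay. Compound 2 `Cc1c(CCC(=O)O)cccc1NC(=O)[C@H](c1ccc(Cl)cc1)C1CCCC1` carries a chlorine on the aromatic ring where compound 1 carries a much larger group. In this assay compound 2 gives 19%. Compound 2 therefore stands lowest of the two numbers, and the gap between it and compound 1 is beyond the usual scatter of this kind of measurement.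

Compound 3 `Cc1c(CCC(=O)O)cccc1NC(=O)[C@H](c1ccc(Cl)cc1)[C@@H](C)C(F)(F)F` has not yet been measured. It differs from compound 2 in one place: 1-(trifluoromethyl)ethyl in place of cyclopentyl on a saturated chain carbon bound to an aromatic carbon and a carbonyl carbon. Within the data shown here, nothing among the measured pairs shows what exchanging cyclopentyl for 1-(trifluoromethyl)ethyl does, so any expectation rests on compound 2 alone. Because compound 2 already sits low at 19%, the room for a further fall is small, and no strong reason for a rise is visible. The expected step from compound 2 to compound 3 in this assay is a number 6 percentage points higher from compound 2 to compound 3 (within the scatter), within the scatter. Compound 3 is estimated at 25%, with a range from 5% to 60%.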

Compound 3, largest response reached (reported as efficacy), in percent of the reference or control that the assay uses: 18%
Compound 3: the middle estimate sits 7 percentage points above what was measured; the range from low to high includes it.
By their numbers in this assay, from the lowest: compounds 3 and 2 (each within the scatter of the next); then compound 1.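

In this assay, putting 1-(trifluoromethyl)ethyl in place of cyclopentyl on a saturated chain carbon bound to an aromatic carbon and a carbonyl carbon gives a number 1 percentage points lower from compound 2 to compound 3 (within the scatter). Among these compounds, this is the first reading at this position, and it shows that, with chlorine on the aromatic ring, the closed five-membered carbon ring can give way to an open group with three fluorines and a defined stereocentre without a change that stands out from the scatter. Nothing measured alongside these compounds says why the two groups read alike in this pair.

The pair says nothing about how the same exchange behaves in the setting of compound 1, which carries a much larger group where compound 2 and compound 3 carry chlorine, and a response near the bottom of the scale, as here, may hide differences that would show in that setting. Also open, from the compounds shown here alone, is how a plain isopropyl, which would keep the branching without the fluorines, or a cyclohexyl, which would keep a closed carbon ring, would read at this same position.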